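The source may report more compounds than this note shows. Statements on the series, on what has been measured and on what is new or still open speak of the compounds shown alone.

Compound 1 `C(=C1\CCCN=C1c1cccnc1)\c1ccc(-n2ccnn2)cc1` and compound 2 `Cc1cc(C)c(/C=C2\CCCN=C2c2cccnc2)c(C)c1` share the same core and differ only in the group carried on the outer benzene ring. In an assay on membranes from brain for displacement of a labelled ligand from Neuronal acetylcholine receptor; alpha4/beta2 (Rattus norvegicus), with a stated time of 3 h (on this read-out lower numbers stand for stronger inhibition and higher numbers for weaker inhibition), compound 1 gives 520 nM, and in the same assay compound 2 gives 520 nM; the two stand level at the digits shown, well within the scatter of repeated measurements. Compound 3 `CC(C)(C)C(=O)Oc1ccc(/C=C2\CCCN=C2c2cccnc2)cc1` has not yet been measured in this assay. Relative to compound 1 it changes in one place: ((tert-butyl)carbonyl)oxy in place of 1H-1,2,3-triazol-1-yl on an aromatic carbon. Within the data shown here, no measured pair differing in a single place is available here, so the expectation rests only on the finding that compound 1 and compound 2 do not separate despite carrying quite different groups at this position. On that basis a step of a 1.1-fold higher number from compound 1 to compound 3 (0.02 log units; within the scatter) is expected, in no set direction and not beyond the scatter. Compound 3 is therefore estimated at 550 nM, with a likely range from 200 nM to 1600 nM.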

Compound 3, inhibition constant: 830 nM
Compound 3: middle estimate off by 1.5-fold (0.18 log units), on the low side, and the stated range covers the measured number.
By their numbers in this assay, from the lowest: compounds 1, 2 and 3 (each within the scatter of the next).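

In this assay, putting ((tert-butyl)carbonyl)oxy in place of 1H-1,2,3-triazol-1-yl gives a 1.6-fold higher number from compound 1 to compound 3 (0.20 log units; within the scatter) and so does not clearly separate the two compounds. Among these compounds, this is the first direct comparison here of compounds that differ in one place, and it shows that at this aromatic carbon, a group with no ring can stand in for one with a five-membered aromatic ring without a change beyond the scatter. No measurement shown here accounts for this result.

From the compounds shown here alone, it remains open whether an amine, a carboxylic acid or a longer chain at this position would also leave the number within the scatter. No group shown so far moves the read-out beyond the scatter, so how strongly this position can affect it is still unknown.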